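Alkyl variation on the ring nitrogen: cyclopropyl to sec-butyl

The compounds below may be only part of what the source reports. "The series", "measured", "known", "first", "only" and "open" are said of these compounds alone.

Measured so far in a functional assay (Nicotiana tabacum); on this read-out lower numbers stand for stronger inhibition and higher numbers for weaker inhibition:
compound 1, `CCCNc1nc(SC)nc2ncccc12`, gives 270 nM
compound 2, `CSc1nc(NC2CC2)c2cccnc2n1`, gives 4900 nM

Compound 2 stands highest of the two numbers in this assay. For the measured compounds named here, its nearest neighbour is compound 1, and the single step between them, an 18-fold higher number from compound 1 to compound 2 (1.26 log units; beyond the scatter), lies beyond the scatter.

Compound 3, `CCC(C)Nc1nc(SC)nc2ncccc12`, is still to be measured in this assay. Its change from compound 2 is sec-butyl in place of cyclopropyl on a nitrogen on an aromatic ring. Going by the values given here, the only measured step that bears on it is an 18-fold higher number from compound 1 to compound 2 (1.26 log units; beyond the scatter), a large one, in which an acyclic chain on the ring nitrogen gave way to the three-membered ring. Among the compounds with values here, the move to compound 3 runs in the opposite sense: the ring leaves and an acyclic chain of four carbons enters, branched rather than straight, and no measured pair shows sec-butyl itself. On that basis a large step down in the number is expected, an 11-fold lower number from compound 2 to compound 3 (1.04 log units; beyond the scatter), taking compound 3 back toward the level of compound 1. The estimate for compound 3 in this assay is 450 nM, expected within 150 nM to 1500 nM.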

Compound 3, half-maximal inhibitory concentration: 860 nM
Estimate against measurement, compound 3: 1.9-fold (0.28 log units) below; the range from low to high includes it.
By their numbers in this assay, from the lowest: compound 1; then compound 3; then compound 2.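

Notes on the alkyl group on the nitrogen. In this assay, the high number of the cyclopropyl compound is not a general feature of this position: a 5.7-fold lower number from compound 2 to compound 3 (0.76 log units; beyond the scatter), with sec-butyl in place of cyclopropyl on a nitrogen on an aromatic ring, so that both acyclic groups shown, in compound 1 and compound 3, now give lower numbers than the three-membered ring in compound 2. For the compounds shown here, the return is only partial, and the new pair gives the first reading of a methyl added to the saturated chain carbon bound to that nitrogen: a 3.2-fold higher number from compound 1 to compound 3 (0.50 log units; beyond the scatter), which leaves the propyl of compound 1 with the lowest number of the three, its steps to both others lying beyond the scatter. Nothing measured on these compounds speaks to the reason for either step.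

Still open, going by these compounds, is whether the ring itself or its small size sets the high number, which a cyclopentyl or cyclohexyl group on the same nitrogen would help to separate, and how a longer straight chain such as pentyl compares with propyl. On these data alone, the methylthio group is the same in all three compounds, so the effect of replacing it with an amine or a methoxy group remains unknown.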